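Swapping Fluoro for Acetyl on a Weakly Inhibiting Core

The compounds below may be only part of what the source reports. "The series", "measured", "known", "first", "only" and "open" are said of these compounds alone.

Three compounds sharing one core have been examined so far. Compound 1 `COc1cc(Cn2cc(COc3cccc(/C=C4/C(=O)Nc5ccccc54)c3)nn2)cc(OC)c1` was tested in a functional assay on HeLa cells (Homo sapiens) for inhibition, read by MTT assay, with a stated time of 48 h (on this read-out higher numbers stand for weaker inhibition and lower numbers for stronger inhibition), and in that assay compound 1 gives 22000 nM. Compound 2 `O=C1Nc2cc(Br)ccc2/C1=C\c1cccc(OCc2cn(Cc3ccccc3)nn2)c1` carries a bromo group on the core, and in this assay compound 2 gives "not determined" (no result reported). Compound 3 `O=C1Nc2ccc(F)cc2/C1=C\c1cccc(OCc2cn(Cc3ccccc3)nn2)c1` carries a fluoro group on the core instead. In this assay compound 3 gives > 50000 nM, which is a limit of the assay and not a number. Compound 3 therefore stands at the limit of > 50000 nM in this assay, at which 1 of the 3 values shown sits, so its inhibition is known only to be weak or absent.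

Compound 4 `CC(=O)c1ccc2c(c1)/C(=C\c1cccc(OCc3cn(Cc4ccccc4)nn3)c1)C(=O)N2` is the next candidate. It differs from compound 3 in one place: acetyl in place of fluoro on an aromatic carbon. No pair of measured compounds differing in a single place exists here, so the size of such a change cannot be read from the numbers shown. What is known is that compound 3 sits at the limit while compound 1, with a different core substituent, gives a high value inside the measurable range. Compound 4 is expected to remain a weak inhibitor, with the expected step of an at least 1.6-fold lower number from compound 3 to compound 4 (0.22 log units; that floor lies within the scatter) having an uncertain sign. The estimate for compound 4 is 30000 nM, within a range from 8000 nM to 100000 nM.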

Compound 4, half-maximal inhibitory concentration: > 50000 nM
Compound 4 gave a limit, no number; the forecaster's own chance of this, stated with the estimate: 45%; middle value at least 1.6-fold (0.22 log units) away from the limit.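

In this assay, among these compounds, compound 3 and compound 4 each give a limit of the assay and not a number, so no step between them can be read. Both sit at the same limit: the limit of > 50000 nM in this assay, at which 2 of the 4 values shown sit. Still open, going by these compounds, is whether acetyl and fluoro at this place differ in inhibition at all, and which group there would give a measurable value.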